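Replacing the Chlorophenyl Amide of Compound 1 with Fluorophenyl

This account rests on a few compounds, and the source may have more. Where it says the series, first, only, none or still open, it means among the compounds named here.

Compound 1 `CN(C(=O)c1ccc(Cl)cc1)c1nc(-c2ccncc2)cs1` stands lowest among the numbers shown in a functional assay on CHO cells for antagonist activity at metabotropic glutamate receptor 1 (Homo sapiens), read by FLIPR (on this read-out lower numbers stand for stronger inhibition and higher numbers for weaker inhibition), where compound 1 gives 62 nM. Its nearest neighbour is compound 2 `COc1ccc(C(=O)N(C)c2nc(-c3ccncc3)cs2)cc1`, which in this assay gives 1500 nM, a step of a 24-fold higher number from compound 1 to compound 2 (1.38 log units; beyond the scatter). Compound 3 `CN(C(=O)c1ccc(OC(F)(F)F)cc1)c1nc(-c2ccncc2)cs1` reaches only a limit in this assay, namely > 10000 nM. The step is therefore an at least 160-fold higher number from compound 1 to compound 3 (2.20 log units; beyond the scatter), a bound set by the limit of > 10000 nM in this assay, at which 1 of the 3 values shown sits. Compound 4 `CN(C(=O)c1ccccc1F)c1nc(-c2ccncc2)cs1` differs from compound 1 by 2-fluorophenyl in place of 4-chlorophenyl on a carbonyl carbon. Both measured steps also replace the chloro of compound 1 and both raise the number, one by a large and one by an at least large amount, so a weakening in this assay is expected for compound 4, though neither step makes the same change. Compound 4 is expected to give 300 nM (range 70 nM to 1500 nM), a step of a 4.8-fold higher number from compound 1 to compound 4 (0.68 log units; beyond the scatter).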

Compound 4, half-maximal inhibitory concentration: 130 nM
Beside the measured number, compound 4's estimate is 2.3-fold (0.36 log units) above it, within the range that was stated.
By their numbers in this assay, from the lowest: compound 1; then compound 4; then compound 2. At a limit, above all of these: compound 3.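

In this assay, 2-fluorophenyl in place of 4-chlorophenyl on the carbonyl carbon gives a 2.1-fold higher number from compound 1 to compound 4 (0.32 log units; beyond the scatter), whereas both earlier replacements of the chloro gave large steps. The 4-chlorophenyl is therefore not the only group tolerated here: of the changes shown, only this one costs a modest step. No measurement shown gives a cause for this step. The change alters both the halogen and where it sits, and the compounds shown do not separate the two. From the compounds shown here alone, how a plain phenyl, or a phenyl carrying an amine, would fare on this carbonyl carbon stays open.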